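Fluoro to nitro on the chalcone ring of compound 3

This account rests on a few compounds, and the source may have more. Where it says the series, first, only, none or still open, it means among the compounds named here.

Compound 3 `O=C(CSC(=S)N[C@H]1CCOC1=O)Nc1ccc(C(=O)/C=C/c2ccc(F)cc2)cc1` gives 45700 nM in a functional assay on MGC-803 cells (Homo sapiens) for cytotoxicity, read by MTT assay, with a stated time of 72 h (on this read-out lower numbers stand for stronger inhibition and higher numbers for weaker inhibition), the highest number of the three measured compounds; compound 2 `O=C(CSC(=S)N[C@H]1CCOC1=O)Nc1ccc(C(=O)/C=C/c2ccc(Br)cc2)cc1` gives 19600 nM, and compound 1 `O=C(CCl)Nc1ccc(C(=O)/C=C/c2ccc([N+](=O)[O-])cc2)cc1` gives 2350 nM. Compound 4 `O=C(CSC(=S)N[C@H]1CCOC1=O)Nc1ccc(C(=O)/C=C/c2ccc([N+](=O)[O-])cc2)cc1` differs from compound 3 by nitro in place of fluoro on an aromatic carbon. Among the measured compounds shown here, no measured step puts nitro in place of another group with the rest held fixed. For the measured compounds named here, the only change on that ring, a 2.3-fold higher number from compound 2 to compound 3 (0.37 log units; beyond the scatter), shows a modest shift. Compound 1 carries nitro but also a different side chain, so its number alone cannot separate the two effects. Compound 4 is therefore expected to give 20000 nM, within 7000 nM to 60000 nM, a step of a 2.3-fold lower number from compound 3 to compound 4 (0.36 log units; beyond the scatter).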

Compound 4, half-maximal inhibitory concentration: 29400 nM
Compound 4: middle estimate off by 1.5-fold (0.17 log units), on the low side, within the range that was stated.
By their numbers in this assay, from the lowest: compound 1; then compounds 2, 4 and 3 (each within the scatter of the next, the first and the last beyond it).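

In this assay the 4-nitrophenyl of compound 4 gives a number within the scatter of both the 4-fluorophenyl (a 1.6-fold lower number from compound 3 to compound 4 (0.19 log units; within the scatter)) and the 4-bromophenyl (a 1.5-fold higher number from compound 2 to compound 4 (0.18 log units; within the scatter)). With nitro held fixed, the side chain can now be read alone: the large group in place of chlorine gives a much bigger step (a 13-fold higher number from compound 1 to compound 4 (1.10 log units; beyond the scatter)). No measurement here explains either result. On these data alone, whether an amine or a carboxylic acid at this ring position would move the number remains open. So does whether the side-chain step holds with fluoro or bromo on the ring.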